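A few compounds are considered here, and "the series" means these few. Any claim that something is new, unique, unknown or untested is made for them only; others in the source may bear on it.

The measured compounds:
compound 1 `O=C(CSc1nc(Nc2ccccc2)c2ccccc2n1)Nc1ccccc1F`; in a functional assay on PC-3 cells (Homo sapiens) for inhibition, read by MTT assay, with a stated time of 72 h (a lower number here means a stronger inhibitor, a higher number a weaker inhibitor), compound 1 gives 12400 nM.
compound 2 `O=C(CSc1nc(Nc2ccccc2)c2ccccc2n1)Nc1ccc(Cl)c(Cl)c1`; in this assay compound 2 gives 12100 nM.
compound 3 `C=CC(=O)Nc1cccc(NC(=O)CSc2nc(Nc3ccccc3Cl)c3ccccc3n2)c1`; in this assay compound 3 gives 14400 nM.

Compound 3 carries the highest of the three numbers, yet its gaps to compound 1 and to compound 2 both lie within the scatter, so the three sit level in this assay. Compound 4 `C=CC(=O)Nc1cccc(NC(=O)CSc2nc(Nc3cccc(F)c3)c3ccccc3n2)c1` differs from compound 3 by 3-fluorophenyl in place of 2-chlorophenyl on a nitrogen on an aromatic ring. For the measured compounds named here, the only single-point step measured, a 1.0-fold lower number from compound 1 to compound 2 (0.01 log units; within the scatter), sits on an amide-type nitrogen, not on the nitrogen on the aromatic ring, so no measured step bears directly on this change, and that one step stayed within the scatter. The step of a 1.0-fold lower number from compound 3 to compound 4 (0.01 log units; within the scatter) is therefore expected to stay within the scatter in this assay. Compound 4 is estimated at 14000 nM, within 6500 nM to 30000 nM.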

Compound 4, half-maximal inhibitory concentration: 5370 nM
Beside the measured number, compound 4's estimate is 2.6-fold (0.42 log units) above it; measured number outside the range, below it.
By their numbers in this assay, from the lowest: compound 4; then compounds 2, 1 and 3 (each within the scatter of the next).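

In this assay, 3-fluorophenyl in place of 2-chlorophenyl on a nitrogen on an aromatic ring gives a 2.7-fold lower number from compound 3 to compound 4 (0.43 log units; beyond the scatter). This is the only step shown that lies beyond the scatter, so the number responds to a change at this position, unlike the one earlier step, which sat on an amide-type nitrogen. Nothing available explains this difference.

The step changes both the halogen and its place on the phenyl, and the compounds shown do not separate the two. Going by these compounds, how 3-chlorophenyl, or a phenyl carrying a methoxy group or an amine, would read on this nitrogen remains open.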